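Terminal amine swaps on the urea side chain

The compounds below may be only part of what the source reports. "The series", "measured", "known", "first", "only" and "open" are said of these compounds alone.

Measured so far:
compound 1 `COc1ncc(-c2ccc3nc(NC(=O)NCCN4CCCC4)sc3c2)cc1NS(=O)(=O)c1ccc(F)cc1`: 360 nM
compound 2 `COc1ncc(-c2ccc3nc(NC(=O)NCCN(C)C)sc3c2)cc1NS(=O)(=O)c1ccc(F)cc1`: 1020 nM
compound 3 `COc1ncc(-c2ccc3nc(NC(=O)NCCN4CCCCC4)sc3c2)cc1NS(=O)(=O)c1ccc(F)cc1`: 750 nM

In a functional assay on U-87MG ATCC cells for antiproliferative activity against U-87 MG (Homo sapiens), read by MTT assay, with a stated time of 72 h (a higher number here means a weaker inhibitor, a lower number a stronger inhibitor), compound 1 gives the lowest number of the three. Compound 3 sits nearest to it and compound 2 furthest, and both separations lie beyond the scatter.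

Compound 4 `COc1ncc(-c2ccc3nc(NC(=O)NCCN4CCN(C)CC4)sc3c2)cc1NS(=O)(=O)c1ccc(F)cc1` carries the change (4-methylpiperazin-1-yl in place of pyrrolidin-1-yl on a saturated chain carbon, two bonds along the chain from an amide-type nitrogen). For the measured compounds named here, two measured steps bear on this, each replacing pyrrolidin-1-yl at the same place: a 2.8-fold higher number from compound 1 to compound 2 (0.45 log units; beyond the scatter) and a 2.1-fold higher number from compound 1 to compound 3 (0.32 log units; beyond the scatter). Both raised the number modestly, beyond the scatter. Between those two replacements themselves, a 1.4-fold lower number from compound 2 to compound 3 (0.13 log units; within the scatter), so the two alternatives to pyrrolidin-1-yl are not separated.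

The group entering in compound 4 is, like piperidin-1-yl, a six-membered non-aromatic ring, and on these two steps a modest rise above compound 1 is expected, roughly a 1.9-fold higher number from compound 1 to compound 4 (0.29 log units; within the scatter). Compound 4 is accordingly estimated at 700 nM, with a range from 320 nM to 1600 nM.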

Compound 4, half-maximal inhibitory concentration: 440 nM
For compound 4 the middle estimate is 1.6-fold (0.20 log units) above the measured one; low and high end bracket the measured number.
By their numbers in this assay, from the lowest: compounds 1, 4, 3 and 2 (each within the scatter of the next, the first and the last beyond it).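

At this place, on a saturated chain carbon two bonds along the chain from an amide-type nitrogen, 4-methylpiperazin-1-yl, unlike dimethylamino and piperidin-1-yl, is not separated from pyrrolidin-1-yl in this assay (a 1.2-fold higher number from compound 1 to compound 4 (0.09 log units; within the scatter)). It is not separated from piperidin-1-yl either (a 1.7-fold lower number from compound 3 to compound 4 (0.23 log units; within the scatter)), but it does stand apart from dimethylamino (a 2.3-fold lower number from compound 2 to compound 4 (0.37 log units; beyond the scatter)), so the larger six-membered ring with its second nitrogen carries no step beyond the scatter against the pyrrolidin-1-yl compound. Nothing at hand gives a reason for these steps.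

Open, as far as these compounds go, is whether morpholin-4-yl or piperazin-1-yl without its methyl would also stay level with pyrrolidin-1-yl here. Also open, from the compounds shown here alone, is how any of these terminal amines would read on a propyl chain in place of the ethyl one.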